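From 3-chlorophenyl to pyridin-2-yl on a sulfonyl sulfur

The source may report more compounds than this note shows. Statements on the series, on what has been measured and on what is new or still open speak of the compounds shown alone.

Measured so far in an ADME assay (liver) for metabolic stability, with Liver microsome (Homo sapiens) as the target, read by LC-MS, using microsomes and NADPH, with a stated time of 5 min, at 37 degrees C; on this read-out higher numbers stand for fast clearance and lower numbers for slow clearance:
Compound 1 `CCn1c([C@@H](C)NS(=O)(=O)c2ccc(Cl)cc2)nc2cc(CO)ccc21` gives 88 mL.min-1.g-1
Compound 2 `CCn1c([C@@H](C)NS(=O)(=O)c2ccc(C#N)cc2)nc2ccc(C(F)(F)F)cc21` gives 34 mL.min-1.g-1
Compound 3 `CCn1c([C@@H](C)NS(=O)(=O)c2cccc(Cl)c2)nc2ccc(C(F)(F)F)cc21` gives > 100 mL.min-1.g-1 as a limit, not a number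
Still unmeasured: compound 4 `CCn1c([C@@H](C)NS(=O)(=O)c2ccccn2)nc2ccc(C(F)(F)F)cc21`

Among the compounds with values here, compound 3 stands at the limit of > 100 mL.min-1.g-1 in this assay, at which 1 of the 3 values shown sits, and is the only compound there. Its true value is therefore unknown, and any step from it can only be estimated.

The change to compound 4 is confined to one group: pyridin-2-yl in place of 3-chlorophenyl on a sulfonyl sulfur describes pyridin-2-yl in place of 3-chlorophenyl on a sulfonyl sulfur, and the rest of the molecule stays the same.

Within the data shown here, one measured step bears on this place. The step of an at least 2.9-fold higher number from compound 2 to compound 3 (0.46 log units; beyond the scatter) is the swap of 4-cyanophenyl for 3-chlorophenyl, and it shows that the group on the sulfur can matter in this assay by more than the usual scatter. Compound 4 loses that same 3-chlorophenyl group, so a move back towards compound 2 at 34 mL.min-1.g-1 is expected, although pyridin-2-yl is a different group from 4-cyanophenyl. The expected change is an at least 2.5-fold lower number from compound 3 to compound 4 (0.39 log units; beyond the scatter) and would mean slower clearance, beyond the scatter. Compound 4 is estimated at 40 mL.min-1.g-1 with an expected range from 15 mL.min-1.g-1 to 95 mL.min-1.g-1 in this assay for this uncertain comparison.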

Compound 4, intrinsic clearance in microsomes: < 3 mL.min-1.g-1
Compound 4: a limit, no number (the forecaster's own chance of this, stated with the estimate: 10%); middle value at least 13-fold (1.12 log units) away from the limit.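

In this assay, within the data shown here, the group on the sulfonyl sulfur turns out to have a far larger reach than the earlier compounds suggested: pyridin-2-yl in place of 3-chlorophenyl gives an at least 33-fold lower number from compound 3 to compound 4 (1.52 log units; beyond the scatter), and compound 3 is itself a limit rather than a number. The gain is not just the loss of 3-chlorophenyl, since pyridin-2-yl in place of 4-cyanophenyl still gives an at least 11-fold lower number from compound 2 to compound 4 (1.05 log units; beyond the scatter), so among these three groups the ring containing nitrogen goes with much the slowest clearance. Compound 4 carries a limit and not a number, and both steps therefore give only a minimum size: the limit of < 3 mL.min-1.g-1 in this assay, at which 1 of the 4 values shown sits.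

The compounds shown leave open whether the ring nitrogen itself matters, which a plain phenyl group or a pyridin-3-yl group on the sulfur would help to settle. They also leave open whether pyridin-2-yl has the same effect when the trifluoromethyl group on the core is replaced, for example by the hydroxymethyl group of compound 1.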